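This account rests on a few compounds, and the source may have more. Where it says the series, first, only, none or still open, it means among the compounds named here.

Compound 1 `Cc1cc(C)c2c(O)cc(-c3ccc4ccccc4c3)nc2n1` is the weakest of the compounds for which a number is known here. In a functional assay on U-251 cells (Homo sapiens) for antiproliferative activity (on this read-out higher numbers stand for weaker inhibition of growth and lower numbers for stronger inhibition of growth), compound 1 gives 15800 nM, the highest of the two numbers shown. Its nearest neighbour on that scale is compound 3 `Cc1cccc(-c2cc(O)c3ccc(C)nc3n2)c1`, which in this assay gives 200 nM, a gap well beyond the usual scatter of this read-out. Compound 2 `Cc1ccnc2nc(-c3cccc4ccccc34)cc(O)c12` sits at a limit of the assay rather than at a number: in this assay compound 2 gives < 10 nM, and the limit of < 10 nM in this assay, at which 1 of the 3 values shown sits, applies to it. Among the measured compounds shown here, no two of these three compounds differ in a single place, so no measured step connects them.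

The compound that follows, compound 4 `Cc1ccnc2nc(-c3ccc4ccccc4c3)cc(O)c12`, is reached from compound 1 by one change: hydrogen in place of methyl on an aromatic carbon. The change removes a methyl on the core of compound 1 while the rest of the molecule is kept.

For the measured compounds named here, since no measured step of this kind is available, the expectation for compound 4 rests on the spread of the three numbers alone. Compound 4 is estimated to give 3000 nM in this assay, with a range from 500 nM to 20000 nM. That estimate means a step of a 5.3-fold lower number from compound 1 to compound 4 (0.72 log units; beyond the scatter), expected to be a moderate gain in potency.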

Compound 4, concentration for 50% growth inhibition: 646 nM
For compound 4 the middle estimate is 4.6-fold (0.67 log units) above the measured one, and the stated range covers the measured number.
By their numbers in this assay, from the lowest: compound 3; then compound 4; then compound 1. At a limit, below all of these: compound 2.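

The replacement of methyl by hydrogen on this aromatic carbon, next to the ring nitrogen, is the only change in a single place among these compounds, and in this assay it gives a 24-fold lower number from compound 1 to compound 4 (1.39 log units; beyond the scatter). This position is therefore not indifferent on this pair: with the rest of the molecule kept, the loss of a methyl group of one carbon goes with much stronger inhibition of growth. The earlier compounds shown here showed only a spread of numbers, and as none of them differed from another in a single place, that spread could not be tied to any one position.

A single pair leaves open whether the size of this step holds on the other compounds shown, and whether an ethyl group, a methoxy group or an amine on the same carbon would give a number nearer to that of compound 1 or to that of compound 4. Compound 2 stands at a limit of the assay and not at a number, so its distance from the other compounds also stays open: the limit of < 10 nM in this assay, at which 1 of the 4 values shown sits.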